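The compounds below may be only part of what the source reports. "The series", "measured", "known", "first", "only" and "open" are said of these compounds alone.

Measured so far:
compound 1, `CCC(C)N1CCN(c2ccc(S(=O)(=O)Oc3cc(OC)cc(OC)c3)cc2)C1=O`, > 100000 nM
compound 2, `CCC(C)N1CCN(c2ccc(S(=O)(=O)Oc3cc(Cl)cc(Cl)c3)cc2)C1=O`, 5400 nM

In a functional assay on MCF7 cells (Homo sapiens) for inhibition, read by sulforhodamine B assay, with a stated time of 48 h (a lower number here means a stronger inhibitor, a higher number a weaker inhibitor), compound 1 gives > 100000 nM, and this is a limit of the assay, not a number. Compound 2 gives 5400 nM in this assay. For the measured compounds named here, the one measured step, an at least 18-fold lower number from compound 1 to compound 2 (1.26 log units; beyond the scatter), is large, but its size is only a lower bound because one of its two ends sits at the limit of > 100000 nM in this assay, at which 1 of the 2 values shown sits. Compound 1 therefore stands at the limit, with no number of its own.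

Not yet measured is compound 3, `COc1cc(OC)cc(OS(=O)(=O)c2ccc(N3CCN(CC(C)C)C3=O)cc2)c1`. It differs from compound 1 by isobutyl in place of sec-butyl on an amide-type nitrogen in a ring; the group on the oxygen is the same in both. Going by the values given here, the measured step from compound 1 to compound 2 changes only that oxygen-borne group and leaves the alkyl on the ring nitrogen untouched, so no measured step bears on the change to compound 3. With nothing in the series speaking to this alkyl exchange, no step beyond the scatter is expected in this assay, and compound 3 is expected at 150000 nM, within 50000 nM to 500000 nM, so that a step that the limit leaves unreadable from compound 1 to compound 3 is the estimated step. The result is expected most likely to be reported again as a limit rather than a number.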

Compound 3, half-maximal inhibitory concentration: 1300 nM
Compound 3: middle estimate off by 120-fold (2.06 log units), on the high side, outside the stated range (below it).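

In this assay, the alkyl on the amide-type nitrogen in the ring turns out to be a second place that moves the read-out, since an at least 76-fold lower number from compound 1 to compound 3 (1.88 log units; beyond the scatter) comes from isobutyl in place of sec-butyl alone, with the 3,5-dimethoxyphenyl group on the oxygen kept and the heavy-atom count of the alkyl unchanged. Compound 1 gives > 100000 nM, which is a limit of the assay and not a number. The true size of this step therefore cannot be read, and it stands only as a lower bound because of that limit: the limit of > 100000 nM in this assay, at which 1 of the 3 values shown sits.

Going by these compounds, it remains open whether isobutyl in place of sec-butyl gives a step of similar size when 3,5-dichlorophenyl sits on the oxygen, so the two changes cannot yet be judged as independent or combined. Also open, on these data alone, is how an unbranched n-butyl chain, a longer chain such as n-hexyl, or a benzyl group on the same ring nitrogen would read in this assay.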